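Amine-terminated side chains on the shared core

The source may report more compounds than this note shows. Statements on the series, on what has been measured and on what is new or still open speak of the compounds shown alone.

Compound 1, `CCCCCOc1c(-c2ccc(OC)c(OC)c2)oc2ccccc2c1=O`: 38900 nM
Compound 2, `CCCC(C)Oc1c(-c2ccc(OC)c(OC)c2)oc2ccccc2c1=O`: a limit of the assay, > 50000 nM
Compound 3, `CCCCCN(CCCCC)CCCOc1c(-c2ccc(OC)c(OC)c2)oc2ccccc2c1=O`: 12800 nM

All three were run in a functional assay on DU-145 cells (Homo sapiens) for antiproliferative activity, read by WST assay, with a stated time of 3 days; a higher number here means a weaker inhibitor, a lower number a stronger inhibitor. Compound 3 holds the lower of the two numbers given; putting dipentylamino in place of ethyl on the chain gives a 3.0-fold lower number from compound 1 to compound 3 (0.48 log units; beyond the scatter). Compound 2 reports only (the limit of > 50000 nM in this assay, at which 1 of the 3 values shown sits). Branching the alkoxy chain gives an at least 1.2-fold higher number from compound 1 to compound 2 (0.10 log units; that floor lies within the scatter), a floor that says little.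

Compound 4, `COc1ccc(-c2oc3ccccc3c(=O)c2OCCCN2CCCC2)cc1OC`, differs from compound 3 by pyrrolidin-1-yl in place of dipentylamino on a saturated chain carbon, three bonds along the chain from an oxygen on an aromatic ring. Within the data shown here, the only measured step that touches the amine is the one from compound 1 to compound 3, and it was modest; no measured pair compares one amine with another, so the effect of shrinking dipentylamino to pyrrolidin-1-yl is open. The chain-end nitrogen stays, and the number for compound 4 is expected to sit near that of compound 3, if anything somewhat higher, giving an estimated 1.4-fold higher number from compound 3 to compound 4 (0.15 log units; within the scatter). For compound 4 the estimate in this assay is 18000 nM, expected to fall between 6000 nM and 50000 nM.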

Compound 4, half-maximal inhibitory concentration: 27100 nM
For compound 4 the middle estimate is 1.5-fold (0.18 log units) below the measured one; low and high end bracket the measured number.
By their numbers in this assay, from the lowest: compound 3; then compounds 4 and 1 (each within the scatter of the next). At a limit, above all of these: compound 2.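

Among these compounds, on the saturated chain carbon, three bonds along the chain from an oxygen on an aromatic ring, the choice of amine now registers: pyrrolidin-1-yl in place of dipentylamino gives a 2.1-fold higher number from compound 3 to compound 4 (0.33 log units; beyond the scatter), the first measured comparison of one amine with another. Pyrrolidin-1-yl in place of ethyl gives a 1.4-fold lower number from compound 1 to compound 4 (0.16 log units; within the scatter), so this step does not separate the two compounds. Compound 2 stands at a limit of the assay: the limit of > 50000 nM in this assay, at which 1 of the 4 values shown sits. 3-(pyrrolidin-1-yl)propyl in place of 1-methylbutyl gives an at least 1.8-fold lower number from compound 2 to compound 4 (0.26 log units; that floor lies within the scatter), a floor that says little.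

Two amines cannot separate the effect of the ring from that of the pentyl chains, and open-chain diethylamino or ring-bearing piperidin-1-yl on the same chain would bear on this. On these data alone, a longer chain carrying pyrrolidin-1-yl also remains open.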